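Swapping cyclopropyl for cyclohexyl on a largely inactive core

The source may report more compounds than this note shows. Statements on the series, on what has been measured and on what is new or still open speak of the compounds shown alone.

Measured compounds:
Compound 1, `O=C1COc2ccc(-c3cccc(NS(=O)(=O)c4ccc(F)cc4)c3)cc2N1C1CC1`, in a functional assay on A549 cells (Homo sapiens) for antiproliferative activity, read by MTT assay, with a stated time of 72 h (a lower number here means a stronger inhibitor, a higher number a weaker inhibitor), gives > 40000 nM, a limit of the assay.
Compound 2, `O=C1COc2ccc(-c3cnc4ccccc4c3)cc2N1C1CCCCC1`, in this assay gives > 40000 nM, also a limit.

Compound 1 stands where every value here stands: the limit of > 40000 nM in this assay, at which 2 of the 2 values shown sit. Compound 3, `O=C1COc2ccc(-c3cccc(NS(=O)(=O)c4ccc(F)cc4)c3)cc2N1C1CCCCC1`, is not yet measured. It differs from compound 1 by cyclohexyl in place of cyclopropyl on an amide-type nitrogen in a ring. Among the measured compounds shown here, with no measured step to lean on, no change beyond the scatter is expected, and the likeliest outcome is another limit. Compound 3 is expected to give 50000 nM (range 15000 nM to 200000 nM), an estimated step that the limit leaves unreadable from compound 1 to compound 3.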

Compound 3, half-maximal inhibitory concentration: 14500 nM
Compound 3: the middle estimate sits 3.4-fold (0.54 log units) above what was measured; the whole stated range lies above it.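

Among the compounds shown here, the earlier compounds gave only limits, so this is the first sign that the group on this nitrogen of the shared core can change the result. In this assay, cyclohexyl in place of cyclopropyl on the amide-type nitrogen gives an at least 2.7-fold lower number from compound 1 to compound 3 (0.44 log units; beyond the scatter). The true size of this step stays unknown because compound 1 rests on a limit: the limit of > 40000 nM in this assay, at which 2 of the 3 values shown sit.

Going by these compounds, whether a longer chain such as n-butyl or a phenyl ring on this nitrogen would lower the number further stays open. So does the outcome with an amine-bearing chain there.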